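Replacing pyrrolidin-1-yl with 1H-imidazol-1-yl in compound 3

The source may hold more compounds than are shown below. What is called first, only, known or untested is meant among the compounds shown, and "the series" means these compounds.

In a functional assay on the whole organism for antagonist activity, with Mus musculus as the target (a lower number here means that less compound is needed, a higher number that more compound is needed for the effect), compound 1 (`CC(=O)N(C)CC#CCN1CCCC1`) gives > 10 mg/kg as a limit and not a number. Compound 2 (`CC(=O)N(C)CC#CCn1ccnc1`) gives > 100 mg/kg as a limit too. Compound 3 (`COC(=O)N(C)CC#CCN1CCCC1`) gives > 10 mg/kg as a limit as well, so it has no readable value to start from.

Compound 4 (`COC(=O)N(C)CC#CCn1ccnc1`) differs from compound 3 in one place: 1H-imidazol-1-yl in place of pyrrolidin-1-yl on a saturated chain carbon bound to a triple-bonded carbon on a saturated chain carbon bound to a triple-bonded carbon.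

For the measured compounds named here, the one measured step is a step that the two limits leave unreadable from compound 1 to compound 3 and it concerns methoxy in place of methyl on a carbonyl carbon, so it hands no size on to this change. The nearest guide is compound 2, which also carries 1H-imidazol-1-yl but has methyl on the carbonyl carbon. Compound 2 stands at > 100 mg/kg as a limit, and this is the only ground for the expectation that follows.

The estimated step is a step that the limit leaves unreadable from compound 3 to compound 4 and its expected direction is toward more compound needed, though its size stays loose with a limit at the starting end. For compound 4 the estimate in this assay is 100 mg/kg with an expected range of 30 mg/kg to 300 mg/kg and a report as a limit is the likeliest outcome.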

Compound 4, dose for half-maximal effect: > 100 mg/kg
Compound 4 gave a limit, no number (the forecaster's own chance of this, stated with the estimate: 85%); the middle value sits exactly at the limit.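

For the compounds shown here, compound 2, compound 3 and compound 4 all stand as limits and not numbers in this assay, so neither the step to compound 4 from compound 3 nor the one from compound 2 can be read. The compounds shown leave open whether 1H-imidazol-1-yl in place of pyrrolidin-1-yl, or methoxy in place of methyl on a carbonyl carbon, shifts the dose at all.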